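Series notes: chloro in place of ethyl at the carbonyl-bearing ring

The compounds below may be only part of what the source reports. "The series", "measured", "known", "first", "only" and "open" are said of these compounds alone.

Measured so far in an assay on isolated protein for inhibition of aldehyde dehydrogenase 1A1 (Homo sapiens), read by spectrophotometry, tested at 10 uM; on this read-out lower numbers stand for less inhibition and higher numbers for more inhibition at the one concentration tested (going by the name of the read-out):
compound 1 `CCc1ccc(C(=O)N2CCN(Cc3nc4ccccc4n3Cc3cccc(C)c3)CC2)cc1` — 67%
compound 2 `O=C(C1CC1)N1CCN(Cc2nc3ccccc3n2Cc2ccc(F)cc2)CC1` — 32.7%
compound 3 `O=C(C1CC1)N1CCN(Cc2nc3ccccc3n2Cc2ccccc2)CC1` — 23.9%

Compound 1 stands highest of the three, and its gaps to compound 2 and to compound 3 both lie beyond the scatter. Among the compounds with values here, the only step between two measured compounds that differ in one place runs from compound 2 to compound 3, hydrogen in place of fluoro on an aromatic carbon, and it reads a number 8.8 percentage points lower from compound 2 to compound 3 (within the scatter), within the scatter.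

Compound 4 `Cc1cccc(Cn2c(CN3CCN(C(=O)c4ccc(Cl)cc4)CC3)nc3ccccc32)c1` is not yet measured. It differs from compound 1 by chloro in place of ethyl on an aromatic carbon. Within the data shown here, the change sits on the ring that carries the carbonyl, whereas the one measured step concerns a halogen on the other ring of the shared core; no measured step touches the same place. Among the measured compounds shown here, the single step with a halogen, from compound 2 to compound 3, was small, so a small step is expected here as well, more likely downward than upward, but not beyond the scatter.

Compound 4 is therefore estimated at 60% in this assay, with a range from 42% to 78%, which means an expected step of a number 7 percentage points lower from compound 1 to compound 4 (within the scatter).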

Compound 4, a percentage reported as inhibition, at one concentration (the size of the read-out at that concentration, not a potency): 23.2%
Compound 4: middle estimate off by 36.8 percentage points, on the high side, outside the stated range (below it).
By their numbers in this assay, from the lowest: compounds 4, 3 and 2 (each within the scatter of the next); then compound 1.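

In this assay, within the data shown here, the change from 4-ethylphenyl to 4-chlorophenyl on the carbonyl gives a number 43.8 percentage points lower from compound 1 to compound 4 (beyond the scatter) and is a large step, so this position on the ring carrying the carbonyl is sensitive to which group it holds, something no earlier pair could show. Among these compounds, the only other single-place step, a number 8.8 percentage points lower from compound 2 to compound 3 (within the scatter), concerns fluoro and hydrogen on the other ring, and its small size does not carry over to this position. No measurement here bears on why exchanging ethyl for chloro at this position goes with so much less inhibition at the one concentration tested.

With one pair at this position, the series cannot yet separate a specific benefit of ethyl from a specific penalty of chloro, and a methyl, a propyl or longer chain, a methoxy, an amine or a carboxylic acid at the same place would help to tell these apart. Also open, going by these compounds, is whether the same exchange gives a step of similar size when the rest of the molecule differs, since it has been read only on the core of compound 1.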